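The source may report more compounds than this note shows. Statements on the series, on what has been measured and on what is new or still open speak of the compounds shown alone.

Three compounds sharing one core have numbers in a functional assay on A549 cells (Homo sapiens) for antiproliferative activity, read by MTT assay, with a stated time of 48 h; a lower number here means a stronger inhibitor, a higher number a weaker inhibitor: compound 1 (`COc1ccc(-c2nn(-c3ccccc3)cc2C(Nc2nc3ccc(OC)cc3s2)c2c(O)ccc3ccccc23)cc1`) at 28100 nM, compound 2 (`COc1ccc2nc(NC(c3cn(-c4ccccc4)nc3-c3cccc(I)c3)c3c(O)ccc4ccccc34)sc2c1`) at 39300 nM and compound 3 (`COc1cccc(-c2nn(-c3ccccc3)cc2C(Nc2nc3ccc(OC)cc3s2)c2c(O)ccc3ccccc23)c1`) at 88100 nM. Compound 3 carries the highest number of the three, and its steps to both others lie beyond the scatter: a 3.1-fold higher number from compound 1 to compound 3 (0.50 log units; beyond the scatter) and a 2.2-fold higher number from compound 2 to compound 3 (0.35 log units; beyond the scatter).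

Compound 4 (`COc1cccc(-c2nn(-c3ccccc3)cc2C(Nc2nc3ccc(Cl)cc3s2)c2c(O)ccc3ccccc23)c1`) differs from compound 3 in one group: chloro in place of methoxy on an aromatic carbon. This is chloro in place of methoxy on an aromatic carbon, turning 6-methoxy-1,3-benzothiazol-2-yl into 6-chloro-1,3-benzothiazol-2-yl.

Among the compounds with values here, no measured step touches this place, as all three concern the substituted phenyl group elsewhere on the core. The closest guide is a 2.2-fold higher number from compound 2 to compound 3 (0.35 log units; beyond the scatter), which read backwards has iodo replacing methoxy and points weakly towards a lower number for compound 4. That guide comes from another place and another group. The step of a 1.4-fold higher number from compound 1 to compound 2 (0.15 log units; within the scatter) also shows no resolved change when 3-iodophenyl replaces 4-methoxyphenyl. A small move towards a lower number in this assay is therefore expected, not clearly beyond the scatter.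

The estimate means a 1.5-fold lower number from compound 3 to compound 4 (0.17 log units; within the scatter) as the expected step. For compound 4 the estimated value is 60000 nM, with an expected range of 25000 nM to 130000 nM.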

Compound 4, half-maximal inhibitory concentration: 49800 nM
For compound 4 the middle estimate is 1.2-fold (0.08 log units) above the measured one, and the stated range covers the measured number.
By their numbers in this assay, from the lowest: compounds 1, 2, 4 and 3 (each within the scatter of the next, the first and the last beyond it).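

Within the data shown here, the 6-methoxy-1,3-benzothiazol-2-yl group is varied here for the first time: in this assay there is a 1.8-fold lower number from compound 3 to compound 4 (0.25 log units; within the scatter) for chloro in place of methoxy, so this exchange on the aromatic carbon gives no resolved change. The earlier steps all lay on the substituted phenyl group, and two of them were beyond the scatter, so among the compounds shown, resolved differences appear only at that phenyl group, while this single reading at the 6-substituent does not resolve one. No measurement shown accounts for this result, and the reading holds only with the 3-methoxyphenyl group on the core.

As far as these compounds go, it remains open whether chloro in place of methoxy would give the same result with the 4-methoxyphenyl or 3-iodophenyl group present, as in compound 1 or compound 2. From the compounds shown here alone, it also remains open whether a different group at this position, such as an amine, a carboxylic acid or a longer alkoxy chain, would produce a step beyond the scatter in either direction.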